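The compounds below may be only part of what the source reports. "The series", "measured", "known", "first", "only" and "open" are said of these compounds alone.

In an assay on cells for binding affinity to Neuropeptide Y receptor type 1 (Homo sapiens) (on this read-out higher numbers stand for weaker inhibition and lower numbers for stronger inhibition), compound 2 `CCc1sc(CCc2cc(OCC(C)(C)C)cc(NCc3cc(Cl)cc(NC(=O)OC(C)C)c3)n2)nc1C` gives 55 nM, the highest number among the three measured compounds. Compound 1 `CC/C=C\CCOc1cc(CCc2nc(C)c(CC)s2)nc(NCc2cc(Cl)cc(NC(=O)OC(C)C)c2)c1` gives 4.7 nM and compound 3 `CCc1sc(CCc2cc(OC3CCCC3)cc(NCc3cc(Cl)cc(NC(=O)OC(C)C)c3)n2)nc1C` gives 11 nM; the step of a 12-fold higher number from compound 1 to compound 2 (1.07 log units; beyond the scatter) and the step of a 5.0-fold lower number from compound 2 to compound 3 (0.70 log units; beyond the scatter) both show that the neopentyloxy group of compound 2 goes with a higher number than the other two groups on the same oxygen. Compound 4 `CCc1sc(CCc2cc(OCCCc3cccnc3)cc(NCc3cc(Cl)cc(NC(=O)OC(C)C)c3)n2)nc1C` differs from compound 2 as follows: 2-(pyridin-3-yl)ethyl in place of tert-butyl on a saturated chain carbon bound to an oxygen on an aromatic ring. Among the measured compounds shown here, the two steps that leave the neopentyloxy group bear on this change, one large and one modest, both toward a lower number; the entering group carries a six-membered aromatic ring with one hetero atom, for which no measured step exists. A lower number is therefore expected for compound 4, by a step of about a 3.7-fold lower number from compound 2 to compound 4 (0.56 log units; beyond the scatter). Compound 4 is estimated at 15 nM, with a range from 4 nM to 60 nM.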

Compound 4, half-maximal inhibitory concentration: 6.5 nM
Estimate against measurement, compound 4: 2.3-fold (0.36 log units) above; measured number inside the range.
By their numbers in this assay, from the lowest: compounds 1, 4 and 3 (each within the scatter of the next, the first and the last beyond it); then compound 2.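

Replacing neopentyl with 3-(pyridin-3-yl)propyl on the oxygen gives an 8.5-fold lower number from compound 2 to compound 4 (0.93 log units; beyond the scatter) in this assay, showing that a chain ending in a six-membered aromatic ring can stand at this position with a low number. Against the other two groups, the results are a 1.7-fold lower number from compound 3 to compound 4 (0.23 log units; within the scatter) and a 1.4-fold higher number from compound 1 to compound 4 (0.14 log units; within the scatter), so compound 4 cannot be ordered against compound 1 or compound 3. Nothing available explains these differences. From the compounds shown here alone, what a 3-phenylpropyl or a 3-(pyridin-4-yl)propyl group on this oxygen would give remains open, as does whether the ring nitrogen matters at all.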